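The source may hold more compounds than are shown below. What is called first, only, known or untested is meant among the compounds shown, and "the series" means these compounds.

Measured so far in a functional assay on cells for positive allosteric modulation of metabotropic glutamate receptor 2 (Homo sapiens), read by fluorescence and calcium flux, with a stated time of 30 min; on this read-out higher numbers stand for an effect only at larger amounts of compound and lower numbers for an effect already at smaller amounts:
compound 1 `Fc1cc(Cl)ccc1-c1ccc(Cn2nnc3c(Br)cccc32)cn1` gives 6 nM;
compound 2 `Brc1ccc(Cn2nnc3c(Br)cccc32)cn1` gives 210 nM.

Among the measured compounds shown here, compound 2 carries the highest number of the two; the only other compound, compound 1, sits well beneath it, as the step of a 35-fold higher number from compound 1 to compound 2 (1.54 log units; beyond the scatter) shows. Compound 3 `Clc1ccc(Cn2nnc3c(Br)cccc32)cn1` takes one change from compound 2: chloro in place of bromo on an aromatic carbon. For the measured compounds named here, no measured step bears directly on it: the single known step concerned a far larger exchange of groups. With nothing shown for so small a change, a move of no more than the scatter is expected, and the estimated step is a 1.2-fold higher number from compound 2 to compound 3 (0.08 log units; within the scatter). For compound 3 in this assay the estimate is 250 nM, in the range 90 nM to 700 nM.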

Compound 3, half-maximal effective concentration: 290 nM
Compound 3: middle estimate off by 1.2-fold (0.06 log units), on the low side; the measured number falls inside the stated range.
By their numbers in this assay, from the lowest: compound 1; then compounds 2 and 3 (each within the scatter of the next).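

At this position, trading one halogen for the other changes little: a 1.4-fold higher number from compound 2 to compound 3 (0.14 log units; within the scatter) stays within the scatter, so chloro and bromo cannot be told apart here. The large step of a 48-fold higher number from compound 1 to compound 3 (1.68 log units; beyond the scatter) shows that compound 3, like compound 2, lies far from compound 1, so losing the 4-chloro-2-fluorophenyl group costs much whichever halogen replaces it. No measurement here gives a reason for either step.

Still open, going by these compounds, is what an amine, a short carbon chain or a plain phenyl ring would do at this position. A plain phenyl ring would help show whether the ring itself or its chloro and fluoro groups matter more.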